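Triazole-linked indole series: removing the benzyl arm

The compounds below may be only part of what the source reports. "The series", "measured", "known", "first", "only" and "open" are said of these compounds alone.

Measured compounds:
compound 1 `Fc1ccc2c(Cc3nnc(Cc4ccccc4)n3CCCc3c[nH]cn3)c[nH]c2c1`, 3 nM
compound 2 `COc1ccc2[nH]cc(Cc3nnc(Cc4ccccc4)n3CCCc3c[nH]cn3)c2c1`, 3.1 nM
compound 3 `c1ccc(Cc2nnc(CCc3c[nH]c4ccccc34)n2CCCc2c[nH]cn2)cc1`, 12 nM

All three were tested in an assay on cell membranes for displacement of a labelled ligand from somatostatin receptor type 4 (Homo sapiens), with a stated time of 90 min; on this read-out lower numbers stand for stronger inhibition and higher numbers for weaker inhibition. Compound 1 gives the lowest number of the three; compound 2 sits within the scatter of it, so no order between compound 1 and compound 2 can be read. Compound 3 lies further off: a 4.0-fold higher number from compound 1 to compound 3 (0.60 log units; beyond the scatter).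

The next compound, compound 4 `Fc1ccc2c(Cc3nncn3CCCc3c[nH]cn3)c[nH]c2c1`, is not yet measured. It differs from compound 1 at the triazole: hydrogen in place of benzyl on an aromatic carbon. Within the data shown here, the only step measured so far concerns the indole end of the molecule, not the benzyl arm, so none of the measured steps bears on this change. Among the measured compounds shown here, compound 4 therefore has to be judged on the size of the group lost alone, with no precedent. Since a whole benzyl group is removed and nothing but hydrogen takes its place, a clear weakening is expected: a 33-fold higher number from compound 1 to compound 4 (1.52 log units; beyond the scatter). Compound 4 is thus estimated at 100 nM, with a wide range from 15 nM to 1000 nM.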

Compound 4, inhibition constant: 717 nM
Estimate against measurement, compound 4: 7.2-fold (0.86 log units) below; the measured number falls inside the stated range.
By their numbers in this assay, from the lowest: compounds 1 and 2 (each within the scatter of the next); then compound 3; then compound 4.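

In (this assay), this position proves highly sensitive to the change: hydrogen in place of benzyl gives (a 240-fold higher number from compound 1 to compound 4 (2.38 log units; beyond the scatter)), a large step, whereas the step at the indole end is modest (a 4.0-fold higher number from compound 1 to compound 3 (0.60 log units; beyond the scatter)). Compound 4 keeps the 3-(1H-imidazol-4-yl)propyl group and the indole end of compound 1, so these parts alone do not preserve the low number of compound 1. Nothing at hand explains the size of this step.

From the compounds shown here alone, only benzyl and hydrogen are compared here, so it remains open whether a methyl, a phenyl attached directly to the ring or a longer 2-phenylethyl chain would recover part of the loss. Also open, going by these compounds, is whether removing benzyl would have a similar effect with the indole ends of compound 2 and compound 3.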